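Swapping trifluoromethoxy for ethynyl on compound 3

A few compounds are considered here, and "the series" means these few. Any claim that something is new, unique, unknown or untested is made for them only; others in the source may bear on it.

In a physicochemical assay for solubility, read by spectrophotometry, in phosphate buffer, with a stated time of 18 h, at pH 7.4 (on this read-out lower numbers stand for lower solubility and higher numbers for higher solubility), compound 1 `CCc1ccc(-c2nc3c(c(C)nn3-c3ccccc3)c(-c3ccccc3Cl)c2C#N)cc1` gives 1700 nM, compound 2 `CCc1ccc(-c2nc3c(c(C)nn3-c3ccccc3)c(-c3ccccc3F)c2C#N)cc1` gives 1700 nM and compound 3 `CCc1ccc(-c2nc3c(c(C)nn3-c3ccccc3)c(-c3ccccc3OC(F)(F)F)c2C#N)cc1` gives 9900 nM, the highest of the three numbers. The next structure is compound 4 `C#Cc1ccccc1-c1c(C#N)c(-c2ccc(CC)cc2)nc2c1c(C)nn2-c1ccccc1`, not yet measured: ethynyl in place of trifluoromethoxy on an aromatic carbon. In short, ethynyl in place of trifluoromethoxy on an aromatic carbon.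

Three measured steps at this same place bear on the change. The step of no change at the digits printed from compound 1 to compound 2 (within the scatter) stays within the scatter, while a 5.8-fold higher number from compound 1 to compound 3 (0.77 log units; beyond the scatter) and a 5.8-fold higher number from compound 2 to compound 3 (0.77 log units; beyond the scatter) are modest and beyond it. Going by the values given here, no measurement yet covers ethynyl, so any reading is a judgement. Here ethynyl is taken to sit nearer chloro and fluoro than trifluoromethoxy, with only the step of a 5.8-fold higher number from compound 2 to compound 3 (0.77 log units; beyond the scatter) as a guide to size, and that step is expected to be largely undone. The expected change in this assay is a modest fall, a 4.0-fold lower number from compound 3 to compound 4 (0.60 log units; beyond the scatter). The estimate for compound 4 is 2500 nM, with an expected range of 800 nM to 8000 nM.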

Compound 4, solubility: 46000 nM
Compound 4: middle estimate off by 18-fold (1.26 log units), on the low side, and the stated range ends below it.
By their numbers in this assay, from the lowest: compounds 1 and 2 (each within the scatter of the next); then compound 3; then compound 4.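

In this assay, ethynyl gives the highest number of the four compounds at this aromatic carbon, ortho to a large group, with a 4.6-fold higher number from compound 3 to compound 4 (0.67 log units; beyond the scatter). Against the halogens the gap is wider, with a 27-fold higher number from compound 2 to compound 4 (1.43 log units; beyond the scatter) and a 27-fold higher number from compound 1 to compound 4 (1.43 log units; beyond the scatter), so this position supports a much larger spread than the earlier compounds showed, and trifluoromethoxy no longer marks its top end. No evidence is available here to explain the rise.

As far as these compounds go, it remains open whether the rise belongs to ethynyl itself or extends to related groups at this place, such as a propynyl chain, a methoxy or an amine. Also open, from the compounds shown here alone, is whether ethynyl gives a similar step when the ethyl group or the other parts of the shared core are changed.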